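Swapping Fluoro for Methyl on the Outer Ring

A few compounds are considered here, and "the series" means these few. Any claim that something is new, unique, unknown or untested is made for them only; others in the source may bear on it.

Going by the values given here, compound 1 `CC1CCN(C2CCN(S(=O)(=O)c3cccc(-c4ccc(F)cc4)c3)CC2)CC1` holds the lowest of the two numbers measured so far in a functional assay on DLD-1 cells (Homo sapiens) for antiproliferative activity, read by CellTiter-Glo, with a stated time of 72 h; on this read-out higher numbers stand for weaker inhibition and lower numbers for stronger inhibition: compound 1 gives 12 nM. The other measured compound, compound 2 `COc1ccc(S(=O)(=O)N2CCC(N3CCC(C)CC3)CC2)cc1OC`, gives 138 nM in this assay, and the gap between the two lies beyond the usual scatter, so compound 1 stands clearly stronger of the pair.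

Compound 3 `Cc1ccc(-c2cccc(S(=O)(=O)N3CCC(N4CCC(C)CC4)CC3)c2)cc1` is compound 1 with one change, (methyl in place of fluoro on an aromatic carbon), sitting on an aromatic carbon of a six-membered aromatic ring of carbon only, para to a large group; cut one bond further out, 4-fluorophenyl becomes 4-methylphenyl. Among the compounds with values here, no measured pair differs at this place, so the size of the step rests on expectation alone. A change of this kind is expected to move the number little, with the step from compound 1 to compound 3 estimated at a 1.3-fold higher number from compound 1 to compound 3 (0.10 log units; within the scatter), within the scatter. For compound 3 the estimate is 15 nM, expected to fall between 5 nM and 50 nM.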

Compound 3, half-maximal inhibitory concentration: 11 nM
Beside the measured number, compound 3's estimate is 1.4-fold (0.13 log units) above it, within the range that was stated.
By their numbers in this assay, from the lowest: compounds 3 and 1 (each within the scatter of the next); then compound 2.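

In this assay, this place now has its first measured step, a 1.1-fold lower number from compound 1 to compound 3 (0.04 log units; within the scatter), so fluoro and methyl cannot be told apart here. The outer ring thus carries either group on this aromatic carbon, para to a large group, and the number stays within the scatter of that of compound 1. Nothing on hand explains why the two groups read alike.

Each of these groups counts a single heavy atom, so the compounds shown leave open how the number would respond to a larger group here, such as a methoxy, a morpholine or a longer chain like propyl. They also leave open what a carboxylic acid or an amine would do at this carbon, and what plain hydrogen would give there.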